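Methylating the sulfonylurea nitrogen: from compound 2 to compound 3

The source may report more compounds than this note shows. Statements on the series, on what has been measured and on what is new or still open speak of the compounds shown alone.

Measured in a functional assay on thoracic aorta (Rattus norvegicus, strain Wistar), with a stated time of 15 min (a lower number here means that less compound is needed, a higher number that more compound is needed for the effect), so far:
compound 1 `COc1ccc(Cl)cc1C(C)NC(=O)N(C)S(=O)(=O)c1ccc(C)cc1` | 13800 nM
compound 2 `COc1ccc(F)cc1C(C)NC(=O)NS(=O)(=O)c1ccc(C)cc1` | > 300000 nM

Compound 2 stands at > 300000 nM in this assay, and this is a limit of the assay, not a number. Among the measured compounds shown here, the series therefore has only one true number so far, and no measured step is available to size the change directly.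

The next compound to be measured is compound 3 `COc1ccc(F)cc1C(C)NC(=O)N(C)S(=O)(=O)c1ccc(C)cc1`, which differs from compound 2 as follows: methyl in place of hydrogen on an amide-type nitrogen, with methyl in place of hydrogen on an amide-type nitrogen. Compound 1 also has a methyl on that nitrogen, and compound 1 gives 13800 nM in this assay as a measured number. This single value is the basis for expecting compound 3 to give a number rather than a limit, although one compound is thin support.

The expected change is a large fall in the concentration needed, well beyond the scatter, and the estimated size is an at least 15-fold lower number from compound 2 to compound 3 (1.17 log units; beyond the scatter) in this assay overall. For compound 3 the estimate is 20000 nM, with an expected range from 6000 nM to 70000 nM in this assay for now.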

Compound 3, half-maximal effective concentration: 11700 nM
Estimate against measurement, compound 3: 1.7-fold (0.23 log units) above, within the range that was stated.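

In this assay, methyl in place of hydrogen on the amide-type nitrogen whose other neighbours are the carbonyl carbon and the sulfonyl sulfur gives an at least 25-fold lower number from compound 2 to compound 3 (1.40 log units; beyond the scatter), the first step read at this position, and compound 3 gives a true number, 11700 nM. This step is a bound on the change and not its full size, because compound 2 stands at a limit of the assay and not at a number: the limit of > 300000 nM in this assay, at which 1 of the 3 values shown sits. With the methyl in place, fluoro in place of chloro on an aromatic carbon gives a 1.2-fold lower number from compound 1 to compound 3 (0.07 log units; within the scatter), so this assay does not separate these two compounds.

The compounds shown leave open whether the methyl step has a similar size with chloro on the aromatic carbon, as the step at this nitrogen can be read only with fluoro. They also leave open whether an ethyl group, a longer chain or an acetyl group on the same nitrogen gives a number close to that of compound 3 or one that differs from it beyond the scatter.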